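Hydroxy in Place of Bromo: Compound 4 Forecast

The source may report more compounds than this note shows. Statements on the series, on what has been measured and on what is new or still open speak of the compounds shown alone.

Compound 1, `COc1cc(-c2nnc3n2NC(c2ccco2)C(C(=O)c2ccc(Br)cc2)S3)cc(OC)c1OC`: in a functional assay on A549 cells (Homo sapiens) for cytotoxicity, read by MTT assay, with a stated time of 48 h (a lower number here means a stronger inhibitor, a higher number a weaker inhibitor), compound 1 gives 42100 nM.
Compound 2, `COc1cc(-c2nnc3n2NC(c2ccco2)C(C(=O)C2CC2)S3)cc(OC)c1OC`: compound 2 reaches only the limit of this assay, > 100000 nM, which is a limit and not a number.
Compound 3, `COc1cc(-c2nnc3n2NC(c2ccco2)C(C(=O)c2ccccc2)S3)cc(OC)c1OC`: compound 3 gives 33400 nM.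

Among the numbers shown, compound 1 sits at the highest, with compound 3 nearest at a 1.3-fold lower number from compound 1 to compound 3 (0.10 log units; within the scatter). The other steps are an at least 2.3-fold higher number from compound 1 to compound 2 (0.37 log units; beyond the scatter) and an at least 2.9-fold lower number from compound 2 to compound 3 (0.47 log units; beyond the scatter), both of which concern the group on the carbonyl carbon and one of which ends at the limit (the limit of > 100000 nM in this assay, at which 1 of the 3 values shown sits).

Compound 4, `COc1cc(-c2nnc3n2NC(c2ccco2)C(C(=O)c2ccc(O)cc2)S3)cc(OC)c1OC`, has not been measured in this assay. The change from compound 1 is hydroxy in place of bromo on an aromatic carbon. Among the measured compounds shown here, only the step from compound 1 to compound 3, which also alters the bromo on that aromatic carbon, bears on it, and that step lay within the scatter. For the measured compounds named here, no step shows a hydroxy at this place. Compound 4 is therefore expected to move little, with a 1.1-fold higher number from compound 1 to compound 4 (0.03 log units; within the scatter) as the estimated step. The estimate for compound 4 in this assay is 45000 nM, with a range from 15000 nM to 130000 nM.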

Compound 4, half-maximal inhibitory concentration: 93400 nM
Compound 4: middle estimate off by 2.1-fold (0.32 log units), on the low side; the measured number falls inside the stated range.
By their numbers in this assay, from the lowest: compounds 3 and 1 (each within the scatter of the next); then compound 4. At a limit, above all of these: compound 2.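

In this assay, bromo and hydrogen on the aromatic carbon para to a large group had not separated, so this place had shown no sensitivity to what it carries. Hydroxy is the first group there to move the number beyond the scatter, with a 2.2-fold higher number from compound 1 to compound 4 (0.35 log units; beyond the scatter) and a 2.8-fold higher number from compound 3 to compound 4 (0.45 log units; beyond the scatter), both toward a weaker inhibitor, and the remaining step reads an at least 1.0-fold lower number from compound 2 to compound 4 (0.02 log units; that floor lies within the scatter) at its floor. That remaining step gives only a floor, because compound 2 gives only a limit and not a number: the limit of > 100000 nM in this assay, at which 1 of the 4 values shown sits.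

The compounds shown leave open whether an amine or a carboxylic acid on this aromatic carbon would also raise the number. They also leave open whether hydroxy would do the same on another carbon of this ring, and no cause for the rise can be drawn from these values.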